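Pentafluoroethyl in place of bromo on the shared core

The compounds below may be only part of what the source reports. "The series", "measured", "known", "first", "only" and "open" are said of these compounds alone.

Compound 1 `CC1(C)C=C(c2cccc[n+]2[O-])c2cc(Br)ccc2C1=O` and compound 2 `CC1(C)C=C(c2cccc[n+]2[O-])c2cc(Cl)c(Cl)cc2C1=O` share one core and differ only in the substituents on its carbon-only aromatic ring. In a functional assay with Rattus norvegicus as the target (on this read-out higher numbers stand for weaker inhibition and lower numbers for stronger inhibition), compound 1 gives 810 nM, and compound 2 gives 470 nM; the two numbers sit within the usual scatter of each other, so neither can be called the stronger inhibitor. Compound 3 `CC1(C)C=C(c2cccc[n+]2[O-])c2cc(C(F)(F)C(F)(F)F)ccc2C1=O` is not yet measured. It differs from compound 1 by 1,1,2,2,2-pentafluoroethyl in place of bromo on an aromatic carbon. Within the data shown here, with no measured step to lean on, the expected step of a 1.1-fold higher number from compound 1 to compound 3 (0.05 log units; within the scatter) is small, in no clear direction. Compound 3 is estimated at 900 nM, within 300 nM to 2700 nM.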

Compound 3, half-maximal inhibitory concentration: 590 nM
Compound 3: the middle estimate sits 1.5-fold (0.18 log units) above what was measured, and the stated range covers the measured number.
By their numbers in this assay, from the lowest: compounds 2, 3 and 1 (each within the scatter of the next).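

The step of a 1.4-fold lower number from compound 1 to compound 3 (0.14 log units; within the scatter) shows that, at this aromatic carbon, a single bromine atom can give way to a chain of 7 heavy atoms without a change that can be read in this assay. So the size of the group at this position, across this one swap, does not separate the two compounds. Nothing shown explains this result.

As far as these compounds go, whether an amine or a carboxylic acid at this carbon would shift the number remains open. It is also unknown whether any group here moves the read-out beyond the scatter.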